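Nitro for Dichloro on the Second Double-Bond Geometry

The source may hold more compounds than are shown below. What is called first, only, known or untested is meant among the compounds shown, and "the series" means these compounds.

Compound 1 `O=C(OC/C(=C\c1ccc(Cl)cc1Cl)C(=O)c1ccccc1)c1ccccc1` and compound 3 `O=C(OC/C(=C/c1ccc(Cl)cc1Cl)C(=O)c1ccccc1)c1ccccc1` are the two cores of this set, and their difference is the two compounds have the same atoms and bonds and differ only in configuration as drawn: 1 of 1 stereo elements differ; a double bond is drawn E in compound 1 and Z in compound 3. In a functional assay on HeLa cells (Homo sapiens) for inhibition, read by sulforhodamine B assay, with a stated time of 48 h (on this read-out higher numbers stand for weaker inhibition of growth and lower numbers for stronger inhibition of growth), compound 1 gives 20000 nM, while compound 3 gives 8300 nM, so a 2.4-fold lower number from compound 1 to compound 3 (0.38 log units; beyond the scatter). What can be pointed to for that step is the fact that compounds 1 and 3 differ only in the configuration as drawn. Compound 2 `O=C(OC/C(=C\c1ccccc1[N+](=O)[O-])C(=O)c1ccccc1)c1ccccc1` differs from compound 1 by 2-nitrophenyl in place of 2,4-dichlorophenyl on a double-bonded chain carbon bound to a double-bonded chain carbon; in this assay compound 2 gives 22000 nM, which is a 1.1-fold higher number from compound 1 to compound 2 (0.04 log units; within the scatter). Compound 3 thus carries the lowest number of the three measured compounds.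

Compound 4 `O=C(OC/C(=C/c1ccccc1[N+](=O)[O-])C(=O)c1ccccc1)c1ccccc1` is not yet measured. Against compound 3 it carries the same change, (2-nitrophenyl in place of 2,4-dichlorophenyl on a double-bonded chain carbon bound to a double-bonded chain carbon), now set on the core of compound 3 rather than that of compound 1, the two cores differing as told above. Resting on the step of a 1.1-fold higher number from compound 1 to compound 2 (0.04 log units; within the scatter) seen for compound 2, the step expected for compound 4 is a 1.1-fold higher number from compound 3 to compound 4 (0.04 log units; within the scatter). Compound 4 is therefore estimated at 9000 nM, within 4000 nM to 20000 nM.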

Compound 4, concentration for 50% growth inhibition: 30000 nM
Compound 4: the middle estimate sits 3.3-fold (0.52 log units) below what was measured; the whole stated range lies below it.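

On the second core, in this assay, 2-nitrophenyl in place of 2,4-dichlorophenyl gives a 3.6-fold higher number from compound 3 to compound 4 (0.56 log units; beyond the scatter), so the change does not carry over unaltered from the first core: the same change on two cores in this assay, a 1.1-fold higher number (0.04 log units; within the scatter) from compound 1 to compound 2 and a 3.6-fold higher number (0.56 log units; beyond the scatter) from compound 3 to compound 4, 3.3-fold (0.52 log units) apart, beyond the scatter of two such steps. The double-bond geometry, which separates the two 2,4-dichlorophenyl compounds, does not separate the two 2-nitrophenyl compounds, with a 1.4-fold higher number from compound 2 to compound 4 (0.13 log units; within the scatter): the fact that compounds 2 and 4 differ only in the configuration as drawn. In these four compounds the size of the step therefore depends on the core it is set on, but a single change on a single pair of cores does not show why, nor whether any other group would behave the same way.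

The compounds shown leave open whether this dependence on geometry also appears with other groups at the same place, such as an unsubstituted phenyl or a methoxyphenyl. They also leave open whether it persists when the ester of the shared core gives way to an amide or an amine.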